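Lengthening the Amide Chain from Nonyl to Dodecyl

The source may report more compounds than this note shows. Statements on the series, on what has been measured and on what is new or still open speak of the compounds shown alone.

The measured compounds, each tested in an assay on cell membranes for binding affinity to 2-oxoglutarate receptor 1 (Rattus norvegicus), read by radioligand binding; on this read-out higher numbers stand for weaker inhibition and lower numbers for stronger inhibition:
Compound 1, `CCCCCCNC(=O)[C@H]1OC(n2cnc3c(N)ncnc32)[C@H](O)[C@@H]1O`, gives 19 nM.
Compound 2, `CCCCCCCNC(=O)[C@H]1OC(n2cnc3c(N)ncnc32)[C@H](O)[C@@H]1O`, gives 20 nM.
Compound 3, `CCCCCCCCCNC(=O)[C@H]1OC(n2cnc3c(N)ncnc32)[C@H](O)[C@@H]1O`, gives 31 nM.

Compound 3 gives the largest of the three numbers, but the step of a 1.6-fold higher number from compound 2 to compound 3 (0.19 log units; within the scatter) and the step of a 1.6-fold higher number from compound 1 to compound 3 (0.21 log units; within the scatter) both lie within the scatter, so no real difference among the three is established.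

Compound 4, `CCCCCCCCCCCCNC(=O)[C@H]1OC(n2cnc3c(N)ncnc32)[C@H](O)[C@@H]1O`, differs from compound 3 by propyl in place of hydrogen on a saturated chain carbon, nine bonds along the chain from an amide-type nitrogen. The measured steps that bear on this are the earlier extensions of the same chain: a 1.1-fold higher number from compound 1 to compound 2 (0.02 log units; within the scatter), a 1.6-fold higher number from compound 1 to compound 3 (0.21 log units; within the scatter) and a 1.6-fold higher number from compound 2 to compound 3 (0.19 log units; within the scatter). Each lengthened the chain hanging from the amide, and none moved the number beyond the scatter, though all three leaned toward slightly higher numbers. A further extension by propyl is therefore expected to give, at most, a small step toward a higher number in this assay, and possibly none beyond the scatter. Compound 4 is estimated at 45 nM, within 20 nM to 110 nM. This estimate means an expected step of a 1.5-fold higher number from compound 3 to compound 4 (0.16 log units; within the scatter), a drift in the same direction as the steps already seen.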

Compound 4, inhibition constant: 163 nM
Estimate against measurement, compound 4: 3.6-fold (0.56 log units) below; the measured number lies above the stated range.
By their numbers in this assay, from the lowest: compounds 1, 2 and 3 (each within the scatter of the next); then compound 4.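

In this assay, for the compounds shown here, the chain on the amide does not tolerate unlimited lengthening: propyl in place of hydrogen, nine bonds along the chain from the amide-type nitrogen, gives a 5.3-fold higher number from compound 3 to compound 4 (0.72 log units; beyond the scatter) and is the first step to pass the scatter. Comparison with the shorter chains points the same way, with an 8.2-fold higher number from compound 2 to compound 4 (0.91 log units; beyond the scatter) and an 8.6-fold higher number from compound 1 to compound 4 (0.93 log units; beyond the scatter) as well, so compound 4 is the weakest of the four, while compound 1, compound 2 and compound 3 cannot be told apart. Nothing measured here explains why the number rises at the dodecyl length.

The compounds shown leave open where between nonyl and dodecyl the rise begins, and whether a decyl or undecyl chain would read like compound 3 or like compound 4. They also leave open whether a longer chain than dodecyl would raise the number further, and how a chain carrying an amine or a carboxylic acid would compare with the plain dodecyl chain of compound 4.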